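The compounds below may be only part of what the source reports. "The series", "measured", "known", "first", "only" and "open" are said of these compounds alone.

Compound 1 `CCc1ccccc1Nc1ncc2cc(Oc3ccnc(C(=O)NC)c3)ccc2n1` in a physicochemical assay for solubility, at pH 7 (a lower number here means a less soluble compound, a higher number a more soluble compound), gives a limit, < 1000 nM. Compound 2 `CNC(=O)c1cc(Oc2ccc3nc(Nc4cccc(C(F)(F)F)c4)ncc3c2)ccn1` gives a limit, < 1000 nM.

Compound 2 therefore stands at the limit of this assay, the position at which both shown values sit (the limit of < 1000 nM in this assay, at which 2 of the 2 values shown sit). Within the data shown here, the only measured step, a step that the two limits leave unreadable from compound 1 to compound 2, is unreadable, so no size for a change of this kind is known. Compound 3 `CNC(=O)c1cc(Oc2ccc3nc(Nc4ccc(OC)cc4)ncc3c2)ccn1` differs from compound 2 by 4-methoxyphenyl in place of 3-(trifluoromethyl)phenyl on a nitrogen on an aromatic ring. With no readable step to lean on, the step to compound 3 is estimated as a step that the limit leaves unreadable from compound 2 to compound 3, not beyond the scatter. Compound 3 is expected at 800 nM, within 200 nM to 3000 nM.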

Compound 3, solubility: < 1000 nM
Compound 3: only a limit was reported; the forecaster's own chance of this, stated with the estimate: 65%; the middle value lies beyond the limit too.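

Compound 1, compound 2 and compound 3 all give only a limit in this assay, so no step among them can be read: the limit of < 1000 nM in this assay, at which 3 of the 3 values shown sit.

On these data alone, the actual values in this assay, and whether exchanging the group on the nitrogen changes them, remain open.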